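The compounds below may be only part of what the source reports. "The series", "measured", "known", "first", "only" and "open" are said of these compounds alone.

Compound 1 `CC1CCN(c2c(S(=O)(=O)c3cccc(Cl)c3)cnc3ccc(Cl)cc23)CC1` is tested in an assay on isolated protein for displacement of a labelled ligand from metabotropic glutamate receptor 5 (Homo sapiens), with a stated time of 60 min, tested at 1 uM (a higher number here means more inhibition at the concentration tested (going by the name of the read-out), a lower number less inhibition), where compound 1 gives 92%. Compound 3 `CC1CCN(c2c(S(=O)(=O)c3cccc(Cl)c3)cnc3ccc(F)cc23)CC1` gives 92%, and the step of no change at the digits printed from compound 1 to compound 3 (within the scatter) leaves the number where it was, so these two stand together at the top of the three. Within the data shown here, compound 2 `COc1ccc(S(=O)(=O)c2cnc3ccc(C)cc3c2N2CCC(C)CC2)cc1` gives 62%, a lower number, but it differs from compound 1 in more than one place, so no single step connects them. Compound 4 `COc1ccc(S(=O)(=O)c2cnc3ccc(Cl)cc3c2N2CCC(C)CC2)cc1Cl` differs from compound 1 by methoxy in place of hydrogen on an aromatic carbon. Among the measured compounds shown here, no measured step matches this change; compound 2 is the only measured compound carrying a methoxy, and its lower value is the only hint available. Compound 4 is therefore expected to lose a little, a number 12 percentage points lower from compound 1 to compound 4 (beyond the scatter), with an estimate of 80% in a range from 55% to 97%.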

Compound 4, a percentage reported as inhibition, at one concentration (the size of the read-out at that concentration, not a potency): 46%
Beside the measured number, compound 4's estimate is 34 percentage points above it; measured number below the stated range.
By their numbers in this assay, from the lowest: compound 4; then compound 2; then compounds 1 and 3 (each within the scatter of the next).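

Going from 3-chlorophenyl to 3-chloro-4-methoxyphenyl is a single change that clearly moves the number in this assay: a number 46 percentage points lower from compound 1 to compound 4 (beyond the scatter). Among these compounds, the only earlier step, fluoro in place of chloro, left the number unchanged, whereas this aromatic carbon, ortho to a chloro group and para to a large group, is a place where adding methoxy matters. Nothing measured here explains the loss.

From the compounds shown here alone, whether a hydroxy group or an amine at this carbon would lower the number as much remains open. Also open, going by these compounds, is whether the loss from methoxy depends on the chloro group being present.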